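Shortening a long chain on a shared core

The compounds below may be only part of what the source reports. "The series", "measured", "known", "first", "only" and "open" are said of these compounds alone.

Of the compounds shown here, three on one shared core have been measured in an assay on HEK293 cells for agonist activity at transient receptor potential cation channel subfamily M member 8 (Homo sapiens), read by fluorescence and calcium flux, with a stated time of 5 min; a higher number here means that more compound is needed for the effect, a lower number that less compound is needed. Compound 1, `C=CCc1cc(OC)c(OC(C)C(OCCCCCCCCCC)c2ccc(O)c(OC)c2)c(OC)c1`, gives 66 nM. Compound 3, `C=CCc1cc(OC)c(O[C@@H](C)[C@@H](OCC)c2ccc(O)c(OC)c2)c(OC)c1`, gives 87 nM; this number is within the usual scatter of that of compound 1, so the two cannot be told apart. Compound 2, `C=CCc1cc(OC)c(O[C@H](C)[C@@H](OC(C)=O)c2ccc(O)c(OC)c2)c(OC)c1`, gives only a limit of the assay, > 10000 nM, which is the limit of > 10000 nM in this assay, at which 1 of the 3 values shown sits. Compound 1 therefore has the lowest number of the two real numbers, but its nearest neighbour, compound 3, sits within the scatter of it.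

Compound 4, `C=CCc1cc(OC)c(OC(C)C(OC)c2ccc(O)c(OC)c2)c(OC)c1`, has not yet been measured. It differs from compound 1 in one place: hydrogen in place of nonyl on a saturated chain carbon bound to an oxygen on a saturated carbon. Within the data shown here, no step between two measured compounds matches this change exactly, so the expectation rests on what compounds 1 and 3 show, namely that two rather different groups on this carbon give numbers that cannot be told apart. A step in this assay of roughly the size seen between compound 1 and compound 3, or somewhat weaker, is expected, if anything towards a higher number. Compound 4 is expected to give 120 nM in this assay, with a range from 40 nM to 400 nM. The step of a 1.8-fold higher number from compound 1 to compound 4 (0.26 log units; within the scatter) is thus estimated to be small.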

Compound 4, half-maximal effective concentration: 3450 nM
Compound 4: middle estimate off by 29-fold (1.46 log units), on the low side, and the stated range ends below it.
By their numbers in this assay, from the lowest: compounds 1 and 3 (each within the scatter of the next); then compound 4. At a limit, above all of these: compound 2.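

In this assay, the group on a saturated chain carbon bound to an oxygen on a saturated carbon clearly matters: putting hydrogen in place of nonyl, which turns decyloxy into methoxy, brings a 52-fold higher number from compound 1 to compound 4 (1.72 log units; beyond the scatter) and lies well beyond the usual scatter. The earlier compounds shown here could not show this, since compound 1 and compound 3 differ in more than one place, and so their similar numbers did not isolate the effect of this group. Among these compounds, this is the first measured change confined to this one place, yet it gives only the size of the step, and nothing measured here explains it.

Compound 3 carries ethoxy but also has a defined spatial arrangement that compound 1 and compound 4 lack, so it does not show whether the number changes gradually or abruptly as the chain grows from methoxy to decyloxy. Also open, from the compounds shown here alone, is how this position would respond to a chain longer than decyl, or to a decyl chain ending in an amine or a carboxylic acid.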